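The source may hold more compounds than are shown below. What is called first, only, known or untested is meant among the compounds shown, and "the series" means these compounds.

In a functional assay on KB cells (Homo sapiens) for inhibition, read by MTT assay, with a stated time of 24 h, tested at 100 ug/mL (on this read-out lower numbers stand for less inhibition of growth and higher numbers for more inhibition of growth at the one concentration tested), the results so far are these:

Compound 1 (`O=C(CCCCC1CCSS1)Nc1ccccc1Cl`) 0.72%
Compound 2 (`O=C(CCCCC1CCSS1)Nc1cccc2ccccc12`) "not active" (no number reported)
Compound 3 (`O=C(CCCCC(S)CCS)Nc1ccc(Cl)cc1`) 44.1%

Compound 2 has no number: it is reported as "not active" (no number reported) and cannot be ranked exactly against the others. Compound 4 (`O=C(CCCCC(S)CCS)Nc1cccc2ccccc12`) differs from it in one place: a group of 5 heavy atoms (3 carbon, 2 sulfur; no ring) in place of a group of 5 heavy atoms (3 carbon, 2 sulfur; one five-membered non-aromatic ring with 2 hetero atoms), on a saturated chain carbon, four bonds along the chain from a carbonyl carbon. Compound 3 also carries 1,3-disulfanylpropyl and gives 44.1%, whereas compound 1 keeps the five-membered ring and gives 0.72%, though these two differ elsewhere as well. On that limited evidence, a rise beyond the usual scatter is expected on going from compound 2 to compound 4 in this assay. For compound 4 the estimated value is 35%, with an expected range from 10% to 60%.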

Compound 4, percent growth inhibition at one concentration: "not active" (no number reported)
No number was reported for compound 4, and the estimate cannot be compared.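

Compound 2 and compound 4 are both reported as "not active" in this assay with no numbers, so no step can be read between them. The compounds shown leave open what replacing the five-membered ring with 1,3-disulfanylpropyl does on its own. No supporting evidence bears on this result.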